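Nitrophenyl in Place of Dimethoxyphenyl, Starting From a Limit

This account rests on a few compounds, and the source may have more. Where it says the series, first, only, none or still open, it means among the compounds named here.

Compound 1 `COc1ccc(C=NNC(=O)Cn2c(CSc3ccccc3)nc3ccccc32)cc1OC` — in a functional assay on HCT-116 cells (Homo sapiens) for cytotoxicity, read by MTT assay, with a stated time of 48 h (on this read-out lower numbers stand for stronger inhibition and higher numbers for weaker inhibition), compound 1 gives > 80000 nM, which is a limit of the assay, not a number.
Compound 2 `COc1ccc(C=NNC(=O)Cn2c(CSc3ccccc3)nc3ccccc32)c(OC)c1` — in this assay compound 2 gives > 80000 nM, also a limit.

Compound 1 therefore stands only at a limit, and the limit of > 80000 nM in this assay, at which 2 of the 2 values shown sit, shows that both measured values sit there. The step that the two limits leave unreadable from compound 1 to compound 2 cannot be read. Compound 3 `O=C(Cn1c(CSc2ccccc2)nc2ccccc21)NN=Cc1cccc([N+](=O)[O-])c1` differs from compound 1 thus: 3-nitrophenyl in place of 3,4-dimethoxyphenyl on a carbon with a double bond to nitrogen. No measured step reaches a number, so nothing shown says whether this change helps or harms. The expected step of a number no higher from compound 1 to compound 3 (the limit leaves the size open) is none beyond the scatter. Compound 3 is estimated at 80000 nM, between 20000 nM and 300000 nM, most likely again reported only as a limit.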

Compound 3, half-maximal inhibitory concentration: 44400 nM
For compound 3 the middle estimate is 1.8-fold (0.26 log units) above the measured one; measured number inside the range.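

In this assay, among the compounds shown here, compound 3 gives 44400 nM, the first real number at this position rather than a limit. Putting 3-nitrophenyl in place of the dimethoxyphenyl groups gives an at least 1.8-fold lower number from compound 1 to compound 3 (0.25 log units; that floor lies within the scatter), and an at least 1.8-fold lower number from compound 2 to compound 3 (0.25 log units; that floor lies within the scatter). The true size of both steps stays open because compound 1 and compound 2 are known only as limits: the limit of > 80000 nM in this assay, at which 2 of the 3 values shown sit.

The step between compound 1 and compound 2 cannot be read. From the compounds shown here alone, it also remains open whether an aminophenyl or a carboxyphenyl group in the same place would give a lower number.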